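A few compounds are considered here, and "the series" means these few. Any claim that something is new, unique, unknown or untested is made for them only; others in the source may bear on it.

Measured in a functional assay on CWR22R cells (Homo sapiens) for antiproliferative activity, read by CCK-8 assay, with a stated time of 6 days (a lower number here means a stronger inhibitor, a higher number a weaker inhibitor), so far:
Compound 1 `CCN(c1ccc(C#N)c(Cl)c1)c1cc(-c2ccncc2)ccc1C` gives 1030 nM
Compound 2 `N#Cc1ccc(N2CCc3cc(-c4cnc5ccccc5c4)ccc32)cc1C(F)(F)F` gives "not determined" (no result reported)
Compound 3 `N#Cc1ccc(N2CCCc3c(-c4cccnc4)cccc32)cc1C(F)(F)F` gives 12300 nM

Compound 1 holds the lower of the two numbers in hand. Compound 3 (12300 nM) lies above it, beyond the scatter, and compound 2 has no number to compare.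

Next comes compound 4 (`CCN(c1ccc(C#N)c(Cl)c1)c1cc(-n2cnc3ccccc32)ccc1C`), not yet measured. The change (1H-benzimidazol-1-yl in place of pyridin-4-yl on an aromatic carbon) puts 1H-benzimidazol-1-yl in place of pyridin-4-yl on an aromatic carbon, para to a methyl group, and leaves the rest of compound 1 as it is. Among the measured compounds shown here, no two measured compounds differ in one place only, so the data give no direct measure of this swap, and the expectation starts from compound 1 (1030 nM) alone. In this assay the estimated step (a 1.2-fold higher number from compound 1 to compound 4 (0.07 log units; within the scatter)) is expected to stay within the scatter, with a slight lean to a higher number. For compound 4 the estimated value is 1200 nM with an expected range from 300 nM to 5000 nM in this read-out.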

Compound 4, half-maximal inhibitory concentration: 3040 nM
Compound 4: the middle estimate sits 2.5-fold (0.40 log units) below what was measured, and the stated range covers the measured number.
By their numbers in this assay, from the lowest: compound 1; then compound 4; then compound 3.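

In this assay this aromatic carbon, para to a methyl group, gives the series its first single-change reading: 1H-benzimidazol-1-yl in place of pyridin-4-yl brings a 3.0-fold higher number from compound 1 to compound 4 (0.47 log units; beyond the scatter), a modest step. The position is therefore not indifferent to its substituent, yet it still tolerates a fused group of 9 heavy atoms in place of a single ring of 6, with a measurable value retained. Nothing available accounts for this step, which remains an observation without an established cause.

Among the compounds shown here, with only two groups compared here, ring size and the number of ring nitrogens cannot be separated. From the compounds shown here alone, it also remains open how this position responds to a non-aromatic group such as morpholine or to a carboxylic acid, and whether any replacement improves on pyridin-4-yl.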